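A few compounds are considered here, and "the series" means these few. Any claim that something is new, unique, unknown or untested is made for them only; others in the source may bear on it.

Measured in an assay on HEK293 cells for agonist activity at Toll-like receptor 8 (Homo sapiens), read by spectrophotometry; on this read-out higher numbers stand for an effect only at larger amounts of compound and lower numbers for an effect already at smaller amounts:
compound 1 `CCCCNc1nc(N)nc(C)c1CCCN1CCCCCC1` gives 178 nM
compound 2 `CCCCNc1nc(N)nc(C)c1CCCN(CC)CC` gives 254 nM
compound 3 `CCCCNc1nc(N)nc(C)c1CCCC` gives 780 nM

Compound 1 shows the lowest number of the three; its gap to compound 2, a 1.4-fold higher number from compound 1 to compound 2 (0.15 log units; within the scatter), lies within the scatter, whereas a 4.4-fold higher number from compound 1 to compound 3 (0.64 log units; beyond the scatter) lies beyond it. Compound 4 `CCCCNc1nc(N)nc(C)c1CCCCCc1ccccc1` is not yet measured. It differs from compound 1 as follows: phenethyl in place of azepan-1-yl on a saturated chain carbon, three bonds along the chain from an aromatic carbon. Among the compounds with values here, two measured steps bear on this change: the loss of azepan-1-yl in a 4.4-fold higher number from compound 1 to compound 3 (0.64 log units; beyond the scatter) and the loss of diethylamino in a 3.1-fold higher number from compound 2 to compound 3 (0.49 log units; beyond the scatter). Within the data shown here, compound 4 likewise carries neither group on that chain carbon; phenethyl is larger than methyl, but no measured compound shows what that adds. A modest rise of the number is therefore expected, a 3.9-fold higher number from compound 1 to compound 4 (0.59 log units; beyond the scatter). In this assay compound 4 is estimated at 700 nM, range 250 nM to 2000 nM.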

Compound 4, half-maximal effective concentration: 830 nM
Compound 4: middle estimate off by 1.2-fold (0.07 log units), on the low side; low and high end bracket the measured number.
By their numbers in this assay, from the lowest: compounds 1 and 2 (each within the scatter of the next); then compounds 3 and 4 (each within the scatter of the next).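

In this assay, the step of a 1.1-fold higher number from compound 3 to compound 4 (0.03 log units; within the scatter) shows that extending the butyl chain with benzyl leaves the number within the scatter. Phenethyl does not stand in for either amine: the steps of a 4.7-fold higher number from compound 1 to compound 4 (0.67 log units; beyond the scatter) and a 3.3-fold higher number from compound 2 to compound 4 (0.51 log units; beyond the scatter) show that a carbon-only group with an aromatic ring does not retain the lower numbers seen with azepan-1-yl and diethylamino. Nothing measured here explains this difference.

As far as these compounds go, whether the lower numbers depend on the chain nitrogen itself or on its distance from the core stays open. A primary amine, a morpholine ring or a shorter chain carrying diethylamino would bear on this.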